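What an Added Methoxy May Do

The source may hold more compounds than are shown below. What is called first, only, known or untested is meant among the compounds shown, and "the series" means these compounds.

In a functional assay (on this read-out higher numbers stand for weaker inhibition and lower numbers for stronger inhibition), compound 1 `CC(C)=CCOc1ccc2c(c1)OC(c1ccc(F)cc1)CC2=O` gives 7320 nM, compound 2 `CC(C)=CCOc1ccc2c(c1)OC(c1ccccc1Cl)CC2=O` gives 8020 nM and compound 3 `COc1ccc(C2CC(=O)c3ccc(OCC=C(C)C)cc3O2)cc1` gives 10200 nM. Compound 3 therefore sits level with the other two, within the scatter of both. Compound 4 `COc1ccc(C2CC(=O)c3ccc(OCC=C(C)C)cc3O2)c(OC)c1` differs from compound 3 by a single change, methoxy in place of hydrogen on an aromatic carbon.

Within the data shown here, no measured step adds a group at this place, so the closest guides are two swaps on the same part of the molecule. One is a 1.4-fold higher number from compound 1 to compound 3 (0.14 log units; within the scatter), with methoxy in place of fluoro on an aromatic carbon. The other is a 1.3-fold higher number from compound 2 to compound 3 (0.10 log units; within the scatter), with 4-methoxyphenyl in place of 2-chlorophenyl on a saturated ring carbon. Neither swap moved the number beyond the scatter, but three compounds are a thin basis, so the range stays wide. The expected change is a 1.0-fold lower number from compound 3 to compound 4 (0.01 log units; within the scatter), with no direction beyond the scatter. The estimate for compound 4 is 10000 nM, within an expected range from 4500 nM to 22000 nM.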

Compound 4, half-maximal inhibitory concentration: 8180 nM
The estimate for compound 4 lay 1.2-fold (0.09 log units) above the measured number; measured number inside the range.
By their numbers in this assay, from the lowest: compounds 1, 2, 4 and 3 (each within the scatter of the next).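

Methoxy in place of hydrogen on this aromatic carbon, ortho to a large group and meta to a methoxy group, gives a 1.2-fold lower number from compound 3 to compound 4 (0.10 log units; within the scatter) in this assay. This is the first step shown that adds a group to this ring rather than swapping one group for another, and the added methoxy leaves the number within the scatter. So this position can carry the extra group without a measurable change in this read-out, though nothing here explains that result.

Going by these compounds, what stays open is whether this position is equally indifferent to groups of another kind, such as an amine or a carboxylic acid. On these data alone, it is also open whether a longer chain, such as butoxy, would move the number beyond the scatter.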